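Swapping the benzamide aryl group on a quinoline amide

The compounds below may be only part of what the source reports. "The series", "measured", "known", "first", "only" and "open" are said of these compounds alone.

Compound 1 `CCN1CCN(c2cc(C)c3cc(NC(=O)c4cc(Cl)cc(Cl)c4)ccc3n2)CC1` is one of three quinoline amides measured in a functional assay on MCF7 cells (Homo sapiens) for antiproliferative activity, read by MTT assay, with a stated time of 72 h; a higher number here means a weaker inhibitor, a lower number a stronger inhibitor. Compound 1 gives 6090 nM, which places it second highest of the three. Compound 2 `CNc1cc(C)c2cc(NC(=O)c3ccc(Cl)c(Cl)c3)ccc2n1` gives 2520 nM in this assay, the lowest number of the set, while compound 3 `Cc1cc(N2CCCC2)nc2ccc(NC(=O)c3ccc(Cl)c(Cl)c3)cc12` gives 26300 nM, the highest. Among the compounds with values here, the one step measured within a single change is a 10-fold higher number from compound 2 to compound 3 (1.02 log units; beyond the scatter), and it concerns the amine on the shared core, not the amide.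

Compound 4 `CCN1CCN(c2cc(C)c3cc(NC(=O)c4ccccc4Br)ccc3n2)CC1` differs from compound 1 at the amide: 2-bromophenyl in place of 3,5-dichlorophenyl on a carbonyl carbon. Within the data shown here, no measured pair tests this part of the molecule, since compound 2 and compound 3 both carry a 3,4-dichlorophenyl group and differ from compound 1 elsewhere as well. The account therefore rests on compound 1 alone, and the expected step of a 2.0-fold higher number from compound 1 to compound 4 (0.29 log units; within the scatter) is a modest move toward a higher number with wide uncertainty. Compound 4 is estimated at 12000 nM, with a likely range from 3000 nM to 50000 nM.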

Compound 4, half-maximal inhibitory concentration: 27500 nM
Beside the measured number, compound 4's estimate is 2.3-fold (0.36 log units) below it; measured number inside the range.
By their numbers in this assay, from the lowest: compound 2; then compound 1; then compounds 3 and 4 (each within the scatter of the next).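

In this assay the swap of 3,5-dichlorophenyl for 2-bromophenyl on a carbonyl carbon gives a 4.5-fold higher number from compound 1 to compound 4 (0.65 log units; beyond the scatter) and so lies beyond the scatter. Within the data shown here, the earlier measured step concerned only the amine on the shared core, so this is the first single change showing that the aryl group on the amide also moves the number, here toward a weaker inhibitor. Nothing shown here accounts for the size or direction of this step.

The swap changes the identity, number and placement of the halogens at once, and the two compounds cannot separate these contributions. As far as these compounds go, how a 2-chlorophenyl group or an unsubstituted phenyl group would read on the core of compound 1 remains open, as does whether the amine and amide changes act independently.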